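Ring swaps on the shared core: working notes

The compounds below may be only part of what the source reports. "The series", "measured", "known", "first", "only" and "open" are said of these compounds alone.

Measured in a functional assay on MKN-45 cells (Homo sapiens) for antiproliferative activity, read by CellTiter-Glo, with a stated time of 3 days; on this read-out higher numbers stand for weaker inhibition and lower numbers for stronger inhibition:
compound 1 `C[C@@H](Oc1c(N)ncc2c(-c3cn[nH]c3)coc12)c1c(Cl)ccc(F)c1Cl` gives 3300 nM
compound 2 `C[C@@H](Oc1c(N)ncc2c(-c3ccccn3)coc12)c1c(Cl)ccc(F)c1Cl` gives 4600 nM
compound 3 `C[C@@H](Oc1c(N)ncc2c(-c3ccncc3)coc12)c1c(Cl)ccc(F)c1Cl` gives 900 nM

Compound 3 stands lowest of the three, with both of its steps beyond the scatter: a 3.7-fold lower number from compound 1 to compound 3 (0.56 log units; beyond the scatter) and a 5.1-fold lower number from compound 2 to compound 3 (0.71 log units; beyond the scatter). By contrast, a 1.4-fold higher number from compound 1 to compound 2 (0.14 log units; within the scatter) stays within it. Compound 4 `C[C@@H](Oc1c(N)ncc2c(C3CCNCC3)coc12)c1c(Cl)ccc(F)c1Cl` carries piperidin-4-yl in place of pyridin-4-yl on an aromatic carbon. Going by the values given here, no measured step replaces an aromatic ring with a non-aromatic one, so these modest steps offer only a rough guide to size. In this assay, the expected change is a modest step towards a higher number, estimated as a 2.2-fold higher number from compound 3 to compound 4 (0.35 log units; beyond the scatter). For compound 4 the estimated value is 2000 nM, with an expected range of 500 nM to 6000 nM.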

Compound 4, half-maximal inhibitory concentration: 3100 nM
Beside the measured number, compound 4's estimate is 1.6-fold (0.19 log units) below it; the range from low to high includes it.
By their numbers in this assay, from the lowest: compound 3; then compounds 4, 1 and 2 (each within the scatter of the next).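

On an aromatic carbon two ring bonds from the ring oxygen, piperidin-4-yl does not match pyridin-4-yl (a 3.4-fold higher number from compound 3 to compound 4 (0.54 log units; beyond the scatter)), so with the same ring size, the aromatic ring of compound 3 gives the better number here. Against the other two aromatic rings, piperidin-4-yl stays within the scatter (a 1.5-fold lower number from compound 2 to compound 4 (0.17 log units; within the scatter); a 1.1-fold lower number from compound 1 to compound 4 (0.03 log units; within the scatter)), leaving compound 3 alone apart from the rest. Nothing on hand accounts for these differences.

Still open, going by these compounds, is how a morpholine ring or an open-chain aminomethyl group would read at this position.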